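This account rests on a few compounds, and the source may have more. Where it says the series, first, only, none or still open, it means among the compounds named here.

Measured so far in this series:
compound 1 `Cc1ccc(-c2ccc(C3(C)CC(S(=O)(=O)c4ccc(F)cc4)=C(c4ccc(/C(N)=N\O)cc4)O3)cc2)cc1` — 13700 nM
compound 2 `CC1(c2ccccc2)CC(S(=O)(=O)c2ccc(F)cc2)=C(c2ccc(/C(N)=N\O)cc2)O1` — 68300 nM
compound 3 `CC1(c2ccc(-c3ccc(/C(N)=N\O)cc3)cc2)CC(S(=O)(=O)c2ccc(F)cc2)=C(c2ccc(/C(N)=N\O)cc2)O1` — 15300 nM

In an ADME assay on HepG2 cells (Homo sapiens) for cytotoxicity, read by MTT assay, with a stated time of 72 h (a lower number here means that less compound is tolerated, a higher number that more compound is tolerated), compound 3 stands second highest of the three numbers, with compound 1 within the scatter and only compound 2 clearly apart: a 4.5-fold lower number from compound 2 to compound 3 (0.65 log units; beyond the scatter), whereas a 1.1-fold higher number from compound 1 to compound 3 (0.05 log units; within the scatter). Compound 4 `CC1(c2ccc(-c3ccncc3)cc2)CC(S(=O)(=O)c2ccc(F)cc2)=C(c2ccc(/C(N)=N\O)cc2)O1` differs from compound 3 by a group of 6 heavy atoms (5 carbon, 1 nitrogen; one six-membered aromatic ring with 1 hetero atom) in place of a group of 10 heavy atoms (7 carbon, 2 nitrogen, 1 oxygen; one six-membered aromatic ring of carbon only), on an aromatic carbon. Within the data shown here, the step bearing most directly on this is the one from compound 1, where a different group on the same aromatic carbon left the number within the scatter; the larger shift seen with compound 2 accompanied a hydrogen at that carbon, which compound 4 does not have. A step within the scatter is therefore expected in this assay, a 1.0-fold lower number from compound 3 to compound 4 (0.01 log units; within the scatter). Compound 4 is estimated at 15000 nM, range 7000 nM to 35000 nM.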

Compound 4, half-maximal cytotoxic concentration: 30300 nM
The estimate for compound 4 lay 2.0-fold (0.31 log units) below the measured number, within the range that was stated.
By their numbers in this assay, from the lowest: compounds 1, 3 and 4 (each within the scatter of the next, the first and the last beyond it); then compound 2.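

In this assay, the ring at this aromatic carbon now matters to a small degree: pyridin-4-yl separates from 4-methylphenyl, a 2.2-fold higher number from compound 1 to compound 4 (0.34 log units; beyond the scatter), but not from the group it replaced, a 2.0-fold higher number from compound 3 to compound 4 (0.30 log units; within the scatter). Even so, no ring here reaches the hydrogen of compound 2, a 2.3-fold lower number from compound 2 to compound 4 (0.35 log units; beyond the scatter). Nothing on hand accounts for these differences. From the compounds shown here alone, whether the ring nitrogen of pyridin-4-yl plays any part remains open, and phenyl at this carbon would test that. Also open, going by these compounds, is where a small amine or a carboxylic acid would fall relative to compound 2 and compound 4.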